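Benzothiazolyl replacing hydroxyphenyl on the pyridine core

The compounds below may be only part of what the source reports. "The series", "measured", "known", "first", "only" and "open" are said of these compounds alone.

Among the compounds with values here, compound 3 `Nc1ccc(S(=O)(=O)N2CCN(c3ncc(C(O)(C(F)(F)F)C(F)(F)F)cc3-c3ccccc3O)CC2)cn1` carries the 2-hydroxyphenyl group and is the one member of the series with a numerical read-out in an ADME assay (liver) for metabolic stability, with Liver microsome (Homo sapiens) as the target, using microsomes and NADPH, with a stated time of 30 min, tested at 1 uM; a higher number here means faster removal of the compound, a lower number slower removal: compound 3 gives 22 mL.min-1.g-1. Compound 1 `Nc1ccc(S(=O)(=O)N2CCN(c3ncc(C(O)(C(F)(F)F)C(F)(F)F)cc3C#CC3CC3)CC2)cn1` sits at the limit of this assay, giving < 14 mL.min-1.g-1. Compound 2 `Nc1ccc(S(=O)(=O)N2CCN(c3ncc(C(O)(C(F)(F)F)C(F)(F)F)cc3C#CCCO)CC2)cn1` likewise sits at the limit, giving < 14 mL.min-1.g-1. Both steps toward compound 3 therefore read as floors: an at least 1.5-fold higher number from compound 1 to compound 3 (0.19 log units; that floor lies within the scatter) and an at least 1.5-fold higher number from compound 2 to compound 3 (0.19 log units; that floor lies within the scatter), with the limit of < 14 mL.min-1.g-1 in this assay, at which 2 of the 3 values shown sit, setting how far they can be read.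

Compound 4 `Nc1ccc(S(=O)(=O)N2CCN(c3ncc(C(O)(C(F)(F)F)C(F)(F)F)cc3-c3ccc4scnc4c3)CC2)cn1` changes the aromatic substituent once more: 1,3-benzothiazol-5-yl in place of 2-hydroxyphenyl on an aromatic carbon. No measured pair in the series exchanges one aromatic ring for another, so the steps shown give no direct size for this change; they only place the two alkynyl compounds at the limit and compound 3 somewhat above it. The expectation for compound 4 is therefore a step of about a 1.1-fold higher number from compound 3 to compound 4 (0.06 log units; within the scatter) in this assay, i.e. no clear movement beyond the scatter in either direction. Compound 4 is estimated at 25 mL.min-1.g-1, with a range of 10 mL.min-1.g-1 to 70 mL.min-1.g-1.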

Compound 4, intrinsic clearance in microsomes: 39 mL.min-1.g-1
Estimate against measurement, compound 4: 1.6-fold (0.19 log units) below; the measured number falls inside the stated range.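

In this assay, exchanging one aromatic group for another at this position gives a 1.8-fold higher number from compound 3 to compound 4 (0.25 log units; within the scatter), so 1,3-benzothiazol-5-yl and 2-hydroxyphenyl cannot be separated here, despite the change from a hydroxyl-bearing single ring to a fused ring pair without a hydrogen-bond donor. Compound 4 also provides readable steps from the alkynyl compounds that clear the scatter, which the steps to compound 3 did not: an at least 2.7-fold higher number from compound 2 to compound 4 (0.44 log units; beyond the scatter), and an at least 2.7-fold higher number from compound 1 to compound 4 (0.44 log units; beyond the scatter). Both are floors rather than full sizes, and their true extent stays unknown: the limit of < 14 mL.min-1.g-1 in this assay, at which 2 of the 4 values shown sit.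

Compound 1 and compound 2 both stand at that limit, so the step between them cannot be read. Also open, from the compounds shown here alone, is how a carboxylic acid or a primary amine at this position would read in this assay.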